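Dimethylaminomethyl for Carbamoyl on a Hydrolase Inhibitor Core

The compounds below may be only part of what the source reports. "The series", "measured", "known", "first", "only" and "open" are said of these compounds alone.

Compound 1 `Cn1nc2c(=O)n(CC3(O)CCN(Cc4ccc(-c5ccco5)cc4Cl)CC3)cnc2c1-c1ccc(C(N)=O)cc1` is the reference point of this short series. For the measured compounds named here, in an assay on isolated protein for inhibition of ubiquitin carboxyl-terminal hydrolase 7 (Homo sapiens), with stated times of 30 min and 2 h (a higher number here means a weaker inhibitor, a lower number a stronger inhibitor), compound 1 gives 80.8 nM, the lowest of the three numbers measured so far. Compound 2 `Cn1nc2c(=O)n(CC3(O)CCN(Cc4ccc(-c5cncs5)cc4Cl)CC3)cnc2c1-c1ccc(CN)cc1` gives 117 nM in this assay, within the scatter of compound 1, while compound 3 `Cn1cc(-c2ccc(CN3CCC(O)(Cn4cnc5c(-c6ccc(CN)cc6)n(C)nc5c4=O)CC3)c(Cl)c2)cn1` gives 291 nM. Going by the values given here, the only single-point step among the measured compounds is a 2.5-fold higher number from compound 2 to compound 3 (0.40 log units; beyond the scatter), which concerns the aryl group on the chlorinated ring and not the position changed here. Compound 4 `CN(C)Cc1ccc(-c2c3ncn(CC4(O)CCN(Cc5ccc(-c6ccco6)cc5Cl)CC4)c(=O)c3nn2C)cc1` differs from compound 1 in that ((dimethylamino)methyl in place of carbamoyl on an aromatic carbon). Among the compounds with values here, no measured step touches this carbamoyl position, and compounds 1 and 2, which differ in two places, show only that an aminomethyl analogue remains within the scatter of compound 1. The expectation is therefore a modest step, most likely toward a higher number, as a 1.9-fold higher number from compound 1 to compound 4 (0.27 log units; within the scatter). Compound 4 is estimated at 150 nM, within a range from 50 nM to 450 nM.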

Compound 4, half-maximal inhibitory concentration: 131 nM
For compound 4 the middle estimate is 1.1-fold (0.06 log units) above the measured one; the range from low to high includes it.
By their numbers in this assay, from the lowest: compounds 1, 2 and 4 (each within the scatter of the next); then compound 3.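

In this assay, for the compounds shown here, (dimethylamino)methyl in place of carbamoyl on the aromatic carbon gives a 1.6-fold higher number from compound 1 to compound 4 (0.21 log units; within the scatter), the first measured step at this position. The carbamoyl group, with its 1 hydrogen-bond donor and its double bond outside aromatic rings, can therefore give way to a group with 0 hydrogen-bond donors and no such double bond without a step beyond the scatter. No measurement shown explains why this exchange is tolerated.

On these data alone, it remains open whether a carboxylic acid or a longer chain, such as 2-(dimethylamino)ethyl, would also stay within the scatter of compound 1 at this position. Aminomethyl is also open, since compound 2 and compound 3 carry it but differ from compound 1 in the aryl group as well.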